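The compounds below may be only part of what the source reports. "The series", "measured", "known", "first", "only" and "open" are said of these compounds alone.

Working notes on the series, read in an ADME assay on PBMC cells (Homo sapiens) for cytotoxicity; a lower number here means that less compound is tolerated, a higher number that more compound is tolerated. Compound 1 (`CC(CCNC(=O)c1c(Cl)cncc1Cl)N1CCC(C(Oc2cccc(F)c2)c2ccc(C(F)(F)F)cc2)CC1`) gives 5400 nM. Compound 3 (`CC(CCNC(=O)c1c(Cl)cncc1Cl)N1CCC(C(Oc2ccc(C(F)(F)F)cc2)c2ccc(C(F)(F)F)cc2)CC1`) gives 3100 nM, which lies within the scatter of the value for compound 1, so these two form the low end of the numbers shown. Compound 2 (`CC(CCNC(=O)c1c(Cl)cncc1Cl)N1CCC(C(Oc2cccc(Cl)n2)c2ccc(C(F)(F)F)cc2)CC1`) reads > 32500 nM, which is a limit of the assay and not a number. Against that limit, the series shows an at least 10-fold lower number from compound 2 to compound 3 (1.02 log units; beyond the scatter).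

The next step leads to compound 4 (`CC(CCNC(=O)c1c(Cl)cncc1Cl)N1CCC(C(Oc2ccccc2C(F)(F)F)c2ccc(C(F)(F)F)cc2)CC1`). The change is 2-(trifluoromethyl)phenyl in place of 4-(trifluoromethyl)phenyl on an oxygen on a saturated carbon, the same atoms joined differently.

Going by the values given here, no measured step moves a group around this ring. The closest evidence is the exchange of one carbon-only aromatic ring for another at the same place, a 1.7-fold lower number from compound 1 to compound 3 (0.24 log units; within the scatter). The two larger steps, an at least 6.0-fold higher number from compound 1 to compound 2 (0.77 log units; beyond the scatter) and an at least 10-fold lower number from compound 2 to compound 3 (1.02 log units; beyond the scatter), both run through the 6-chloropyridin-2-yl group of compound 2, and compound 4 does not carry that group. Only a small move in no firm direction is therefore expected, with nothing beyond the scatter. The expected step is a 1.2-fold higher number from compound 3 to compound 4 (0.09 log units; within the scatter). For compound 4 the estimated value is 3800 nM, with an expected range of 1800 nM to 8000 nM.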

Compound 4, half-maximal cytotoxic concentration: 12500 nM
Beside the measured number, compound 4's estimate is 3.3-fold (0.52 log units) below it; measured number outside the range, above it.
By their numbers in this assay, from the lowest: compounds 3 and 1 (each within the scatter of the next); then compound 4. At a limit, above all of these: compound 2.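

In this assay, the place of the trifluoromethyl group on this ring matters: with the same atoms joined differently, 2-(trifluoromethyl)phenyl in place of 4-(trifluoromethyl)phenyl gives a 4.0-fold higher number from compound 3 to compound 4 (0.61 log units; beyond the scatter), a step beyond the scatter that does not run through the 6-chloropyridin-2-yl group. The exchange of 3-fluorophenyl for 2-(trifluoromethyl)phenyl also gives a 2.3-fold higher number from compound 1 to compound 4 (0.36 log units; beyond the scatter), so exchanging one carbon-only aromatic ring for another at this place can move the number beyond the scatter, which the earlier step between compound 1 and compound 3 did not show. The series also shows an at least 2.6-fold lower number from compound 2 to compound 4 (0.41 log units; beyond the scatter), and that step rests on a limit of the assay and not a number: the limit of > 32500 nM in this assay, at which 1 of the 4 values shown sits.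

The compounds shown leave open whether a methyl group or a nitrile in place of the trifluoromethyl group in 2-(trifluoromethyl)phenyl would give a number near that of compound 4. They also leave open how an amine or a carboxylic acid on this ring would read, and whether the step between the two trifluoromethyl isomers would hold on a different core.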